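What the 2-fluorophenyl of compound 1 may be worth

The source may report more compounds than this note shows. Statements on the series, on what has been measured and on what is new or still open speak of the compounds shown alone.

Compound 1 `CCCCNc1nc(N)nnc1OCc1ccccc1F` is one of three compounds with a number in hand. In an assay on isolated protein for agonist activity at Toll-like receptor 8 (Homo sapiens) (on this read-out lower numbers stand for an effect already at smaller amounts and higher numbers for an effect only at larger amounts of compound), compound 1 gives 560 nM, level at the digits shown with compound 2 `CCC[C@H](CCO)Nc1nc(N)nnc1OCc1nccc(OC)c1OC`, which gives 560 nM in this assay; together they stand lowest of the three. Compound 3 `CCOC(=O)C1=Cc2ccc(-c3cccc(C#N)c3)cc2N=C(N)C1` gives 15000 nM in this assay, a gap from compound 1 that lies beyond the scatter. Compound 4 `CCCCNc1nc(N)nnc1OC` has not yet been measured. It differs from compound 1 by hydrogen in place of 2-fluorophenyl on a saturated chain carbon bound to an oxygen on an aromatic ring. Within the data shown here, no measured pair shows this change, so the expectation rests on the structural change alone. The 2-fluorophenyl is a sizeable part of compound 1, and its loss is expected to raise the number well beyond the scatter. The step expected is a 14-fold higher number from compound 1 to compound 4 (1.15 log units; beyond the scatter). Compound 4 is therefore estimated at 8000 nM, within a range from 2000 nM to 40000 nM.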

Compound 4, half-maximal effective concentration: 2040 nM
Beside the measured number, compound 4's estimate is 3.9-fold (0.59 log units) above it; low and high end bracket the measured number.
By their numbers in this assay, from the lowest: compounds 1 and 2 (each within the scatter of the next); then compound 4; then compound 3.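

In this assay, among these compounds, the exchange of 2-fluorophenyl for hydrogen gives a 3.6-fold higher number from compound 1 to compound 4 (0.56 log units; beyond the scatter), the first reading of this position. The group therefore counts for something beyond the scatter, yet the step is modest, and compound 4 without it still gives 2040 nM. Nothing at hand explains the size of this step.

Whether the ring or its fluorine carries the difference stays open, since an unsubstituted phenyl at this place is not among the compounds shown. As far as these compounds go, how a small alkyl group such as ethyl or a basic amine would fare there also remains unknown.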